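Lengthening the sulfonamide chain while removing its second substituent

The compounds below may be only part of what the source reports. "The series", "measured", "known", "first", "only" and "open" are said of these compounds alone.

Measured compounds:
- compound 1, `CC(C)c1cccc(C(C)C)c1NC(=O)NS(=O)(=O)N(C)C`: 3900 nM
- compound 2, `CCCCN(C)S(=O)(=O)NC(=O)Nc1c(C(C)C)cccc1C(C)C`: 2300 nM
- compound 3, `CCCCN(CC)S(=O)(=O)NC(=O)Nc1c(C(C)C)cccc1C(C)C`: 1200 nM

All three share the same core and differ only in what sits on the sulfonyl sulfur. In an assay on liver for inhibition of sterol O-acyltransferase 1 (Rattus norvegicus), using microsomes (on this read-out lower numbers stand for stronger inhibition and higher numbers for weaker inhibition), compound 2 gives 2300 nM, the second highest of the three numbers; its nearest neighbour is compound 1 and its furthest compound 3, and both gaps lie within the scatter.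

Compound 4, `CCCCCCNS(=O)(=O)NC(=O)Nc1c(C(C)C)cccc1C(C)C`, is not yet measured. Its change from compound 2 is hexylamino in place of butyl(methyl)amino on a sulfonyl sulfur.

Within the data shown here, three measured steps bear on this. Adding carbon on a saturated chain carbon bound to a sulfonamide nitrogen gave a 1.7-fold lower number from compound 1 to compound 2 (0.23 log units; within the scatter) and a 1.9-fold lower number from compound 2 to compound 3 (0.28 log units; within the scatter), each within the scatter; taken together they amount to a 3.3-fold lower number from compound 1 to compound 3 (0.51 log units; beyond the scatter), a modest shift. Among the measured compounds shown here, the move to compound 4 adds chain length but takes away one of the two substituents on that nitrogen, and no measured step shows what removing such a substituent does. The two effects are therefore expected to roughly balance, giving a 1.2-fold lower number from compound 2 to compound 4 (0.06 log units; within the scatter), a step not clearly beyond the scatter. Compound 4 is estimated at 2000 nM in this assay, with a range from 800 nM to 5000 nM.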

Compound 4, half-maximal inhibitory concentration: 8100 nM
The estimate for compound 4 lay 4.1-fold (0.61 log units) below the measured number; the measured number lies above the stated range.
By their numbers in this assay, from the lowest: compounds 3, 2 and 1 (each within the scatter of the next, the first and the last beyond it); then compound 4.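

Among these compounds, with hexylamino on the sulfonyl sulfur, this assay shows the first step at this position toward weaker inhibition, a 3.5-fold higher number from compound 2 to compound 4 (0.55 log units; beyond the scatter) in place of the lower numbers seen as carbon was added in the earlier compounds. The gap is wider against the butyl(ethyl)amino compound, at a 6.8-fold higher number from compound 3 to compound 4 (0.83 log units; beyond the scatter) and against the dimethylamino compound, which has the shortest chains of the four, the result is still a 2.1-fold higher number from compound 1 to compound 4 (0.32 log units; beyond the scatter) so compound 4 is the weakest inhibitor here despite carrying the longest chain. Among the compounds shown here, a longer chain therefore does not by itself bring a lower number at this position: hexylamino is also the only one of the four groups with a single chain and a hydrogen left on the nitrogen, and that difference travels together with the added length.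

Nothing available here explains why the number rises. Still open, from the compounds shown here alone, is how much of the rise belongs to the lost substituent and how much to the chain length, a question that butylamino and hexyl(methyl)amino on the same sulfur would help to separate.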